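Swapping the acid-bearing ring on the sulfonamide arm

The compounds below may be only part of what the source reports. "The series", "measured", "known", "first", "only" and "open" are said of these compounds alone.

Compound 1 `O=C(N[C@H]1C(O)O[C@H](CO)[C@@H](O)[C@@H]1O)c1cccc(-c2ccccc2)c1`: 3200 nM
Compound 2 `O=C(O)c1cccc(S(=O)(=O)NC[C@H]2OC(O)[C@H](NC(=O)c3cccc(-c4ccccc4)c3)[C@@H](O)[C@@H]2O)c1`: 50 nM

In an assay for inhibition of hexokinase-2 (Homo sapiens), read by ADP-Glo, with a stated time of 45 min, in the presence of a further agent that is not named here (a higher number here means a weaker inhibitor, a lower number a stronger inhibitor), compound 2 gives the lower of the two numbers, and its distance from compound 1 lies beyond the scatter. Compound 3 `O=C(N[C@H]1C(O)O[C@H](CNS(=O)(=O)c2cnccc2Cl)[C@@H](O)[C@@H]1O)c1cccc(-c2ccccc2)c1` keeps the shared core and the sulfonamide arm of compound 2 but carries 4-chloropyridin-3-yl in place of 3-carboxyphenyl on a sulfonyl sulfur. Only the acid-bearing ring is exchanged, so a moderate weakening is expected, with the estimated step of a 3.0-fold higher number from compound 2 to compound 3 (0.48 log units; beyond the scatter) in this assay. Compound 3 is therefore estimated at 150 nM, in a range from 40 nM to 600 nM.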

Compound 3, half-maximal inhibitory concentration: 100 nM
The estimate for compound 3 lay 1.5-fold (0.18 log units) above the measured number; the range from low to high includes it.
By their numbers in this assay, from the lowest: compounds 2 and 3 (each within the scatter of the next); then compound 1.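

In this assay the exchange of 3-carboxyphenyl for 4-chloropyridin-3-yl on a sulfonyl sulfur gives a 2.0-fold higher number from compound 2 to compound 3 (0.30 log units; within the scatter) and so shows that a carboxylic acid on this ring is not required for a low number. The sulfonamide arm with the new ring, in place of one oxygen atom, still gives a 32-fold lower number from compound 1 to compound 3 (1.51 log units; beyond the scatter) and so keeps a large step without that acid. No supporting measurement explains these results.
As far as these compounds go, whether a smaller group on the sulfonyl sulfur, such as methyl, could replace the ring remains open. So does the outcome with an amine on the ring in place of the chlorine.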